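Three Analogues at the Limit and a Sulfonamide Newcomer

This account rests on a few compounds, and the source may have more. Where it says the series, first, only, none or still open, it means among the compounds named here.

Compound 3 `COc1ccc([C@H]2CC(=O)N(c3cccc([S+](C)[O-])c3)C2)cc1OC1CCCC1` was examined in a functional assay on HEK293 cells (Homo sapiens) for cytotoxicity; on this read-out higher numbers stand for lower toxicity in this test and lower numbers for higher toxicity in this test. In this assay compound 3 gives only a limit, > 10000 nM, and not a number. Its two close relatives stand the same way. Compound 1 `COc1ccc([C@H]2CC(=O)N(c3ccccc3C#N)C2)cc1OC1CCCC1` gives a limit of > 10000 nM in this assay. Compound 2 `COc1ccc([C@H]2CC(=O)N(c3ccc(C#N)cc3)C2)cc1OC1CCCC1` gives a limit of > 10000 nM in this assay. (the limit of > 10000 nM in this assay, at which 3 of the 3 values shown sit), and so the three steps that connect them, a step that the two limits leave unreadable from compound 1 to compound 2, a step that the two limits leave unreadable from compound 1 to compound 3 and a step that the two limits leave unreadable from compound 2 to compound 3, carry no readable size and point in no direction.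

Compound 4 `COc1ccc([C@H]2CC(=O)N(c3cccc(NS(=O)(=O)c4cc(Br)c(Cl)s4)c3)C2)cc1OC1CCCC1` differs from compound 3 by a group of 11 heavy atoms (4 carbon, 1 nitrogen, 2 oxygen, 2 sulfur, 1 chlorine, 1 bromine; one five-membered aromatic ring with 1 hetero atom) in place of a group of 3 heavy atoms (1 carbon, 1 oxygen, 1 sulfur; no ring), on an aromatic carbon. A group of 3 heavy atoms with no ring leaves, and ((4-bromo-5-chlorothiophen-2-yl)sulfonyl)amino, a group of 11 heavy atoms with one five-membered aromatic ring with 1 hetero atom, enters on an aromatic carbon of a six-membered aromatic ring of carbon only, meta to a large group.

Within the data shown here, none of the measured steps offers a readable size to carry across, so no step beyond the scatter is expected. The step from compound 3 to compound 4 is estimated as a number no higher from compound 3 to compound 4 (the limit leaves the size open). Compound 4 is expected to give about 10000 nM in this assay, within a range from 3000 nM to 30000 nM, most likely again reported as a limit.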

Compound 4, half-maximal cytotoxic concentration: > 10000 nM
Compound 4 was reported as a limit; the forecaster's own chance of this, stated with the estimate: 60%; the middle value sits exactly at the limit.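

Compound 4, like compound 3, is reported in this assay only as a limit, so no size or direction can be read for the step between them: the limit of > 10000 nM in this assay, at which 4 of the 4 values shown sit.

The compounds shown leave open how the four compounds differ in this assay, and whether any group on the shared core would give a readable number there.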